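Swapping selenium for sulfur on an inert isoselenourea core

The source may report more compounds than this note shows. Statements on the series, on what has been measured and on what is new or still open speak of the compounds shown alone.

Measured compounds:
compound 1 `C[Se]/C(=N\C(=O)c1cnc2ccccc2c1)NC(=O)c1cnc2ccccc2c1` in a functional assay on HT-29 cells (Homo sapiens) for cytotoxicity, read by MTT assay, with a stated time of 72 h; on this read-out lower numbers stand for higher toxicity in this test and higher numbers for lower toxicity in this test: > 100000 nM
compound 2 `CS/C(=N\C(=O)c1csc([N+](=O)[O-])c1)NC(=O)c1csc([N+](=O)[O-])c1` in this assay: > 100000 nM

Compound 1 is known only by a limit: in this assay compound 1 gives > 100000 nM, which is a boundary of the test rather than a measured number. The same holds for compound 2, whose value of > 100000 nM in this assay is also a limit. Both results sit at the limit of > 100000 nM in this assay, at which 2 of the 2 values shown sit, so compound 1 stands at the weak end of everything shown, with no number to place it more exactly.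

Compound 3 `CS/C(=N\C(=O)c1cnc2ccccc2c1)NC(=O)c1cnc2ccccc2c1` keeps the core of compound 1 and changes one spot: a group of 2 heavy atoms (1 carbon, 1 sulfur; no ring) in place of a group of 2 heavy atoms (1 carbon, 1 selenium; no ring), on a carbon with a double bond to nitrogen. Going by the values given here, compound 2 carries the same methylsulfanyl group on a different core and is likewise only a limit in this assay, so no measured step suggests that this swap moves the read-out beyond the usual scatter. The expected step of a number no higher from compound 1 to compound 3 (the limit leaves the size open) is therefore none of note, and compound 3 is estimated to give 100000 nM, in the range 40000 nM to 300000 nM, most likely again reported as a limit.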

Compound 3, concentration lethal to 50% of the cells: > 100000 nM
Compound 3 was reported as a limit; the forecaster's own chance of this, stated with the estimate: 85%; the middle value sits exactly at the limit.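

Compound 1 and compound 3 are each known only by a limit in this assay, so putting sulfur in place of selenium gives no step that can be read: the limit of > 100000 nM in this assay, at which 3 of the 3 values shown sit.

The compounds shown leave open whether this swap would change the read-out in a compound that gives an actual number in this assay.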